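From Isoquinoline Amide to Methylpyrrolidine Amide: An Untested Step

This account rests on a few compounds, and the source may have more. Where it says the series, first, only, none or still open, it means among the compounds named here.

Of the compounds shown here, three of this set have been measured in an assay for activation of interferon regulatory factor 3 (Homo sapiens), read by a luciferase reporter, with a stated time of 20 h (a lower number here means that less compound is needed, a higher number that more compound is needed for the effect), and all of them sit at the same limit. Compound 1 `CCCn1c(NC(=O)c2cc(C)nn2CC)nc2cc(C(N)=O)ccc21` reaches only the limit > 100000 nM. Compound 2 `CCCn1c(NC(=O)c2nccc3ccccc23)nc2cc(C(N)=O)cc(OC)c21` likewise reaches only the limit > 100000 nM. Compound 3 `COc1cc(C(N)=O)cc2nc(NC(=O)c3nccc4ccccc34)n(CCCNC(=O)OCc3ccccc3)c12`, which carries (benzyloxycarbonyl)amino in place of hydrogen on a saturated chain carbon, three bonds along the chain from an aromatic nitrogen, also stops at the limit > 100000 nM. Within the data shown here, the one step between compounds differing in a single place, a step that the two limits leave unreadable from compound 2 to compound 3, cannot be read, and the limit of > 100000 nM in this assay, at which 3 of the 3 values shown sit, is the whole of the evidence available.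

Compound 3 thus stands at the limit, alongside every other measured compound. Compound 4 `COc1cc(C(N)=O)cc2nc(NC(=O)C3CCCN3C)n(CCCNC(=O)OCc3ccccc3)c12` differs from it in the amide part: 1-methylpyrrolidin-2-yl in place of isoquinolin-1-yl on a carbonyl carbon. Among the measured compounds shown here, no measured step touches a change on the carbonyl carbon, and no measured compound carries a non-aromatic ring there, so no step size can be carried over to this exchange. For the measured compounds named here, with every compound so far at the limit, compound 4 is expected to show no step beyond the scatter in this assay, and a number no higher from compound 3 to compound 4 (the limit leaves the size open) is estimated to be flat. Compound 4 is therefore estimated at 100000 nM, within a range from 30000 nM to 300000 nM.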

Compound 4, half-maximal effective concentration: > 100000 nM
Compound 4 was reported as a limit; the forecaster's own chance of this, stated with the estimate: 80%; the middle value lies on the limit itself.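

Compound 3 and compound 4 both give only a limit, so no step can be read between them, and the exchange of isoquinolin-1-yl for 1-methylpyrrolidin-2-yl on the carbonyl carbon has no readable size. The compounds shown leave open which structure, if any, would give a measurable number: the limit of > 100000 nM in this assay, at which 4 of the 4 values shown sit.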